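The compounds below may be only part of what the source reports. "The series", "measured", "known", "first", "only" and "open" are said of these compounds alone.

Compound 1 `CCN(CC)S(=O)(=O)c1ccc(S(=O)(=O)N2CCC[C@@H](C(=O)N3CCOCC3)C2)cc1` gives 160 nM in a functional assay on MIA PaCa-2 cells (Homo sapiens) for inhibition, read by MTT assay, with a stated time of 3 days; on this read-out lower numbers stand for stronger inhibition and higher numbers for weaker inhibition.
Compound 2 `CCN(CC)S(=O)(=O)c1ccc(S(=O)(=O)N2CCC[C@@H](C(=O)N[C@H]3CCOC3)C2)cc1` gives 290 nM in this assay.
Compound 3 `CCN(CC)S(=O)(=O)c1ccc(S(=O)(=O)N2CCC[C@@H](C(=O)N[C@@H]3CCOC3)C2)cc1` gives 100 nM in this assay.

Compound 3 carries the lowest of these three numbers, yet the step of a 1.6-fold lower number from compound 1 to compound 3 (0.20 log units; within the scatter) is within the scatter, so these two cannot be told apart on this read-out; only the gap to compound 2, a 2.9-fold lower number from compound 2 to compound 3 (0.46 log units; beyond the scatter), stands out, and the pair differ solely in configuration (the fact that compounds 2 and 3 differ only in the configuration as drawn).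

Compound 4 `CCN(CC)S(=O)(=O)c1ccc(S(=O)(=O)N2CCC[C@@H](C(=O)N3CC[C@H](OC)C3)C2)cc1` is reached from compound 3 by the change (3-methoxypyrrolidin-1-yl in place of (oxolan-3-yl)amino on a carbonyl carbon). The closest guide is the reverse of the step from compound 1 to compound 3: there a cyclic amine on the carbonyl gave way to a ring-bearing amide hydrogen, and the outcome was a 1.6-fold lower number from compound 1 to compound 3 (0.20 log units; within the scatter); the sister step a 1.8-fold higher number from compound 1 to compound 2 (0.26 log units; within the scatter) was likewise within the scatter. Going back to a cyclic amine on the carbonyl, now a 3-methoxypyrrolidin-1-yl with one defined stereocentre, is therefore expected to move the number little, with the stereochemical lesson of a 2.9-fold lower number from compound 2 to compound 3 (0.46 log units; beyond the scatter) as a reminder that a modest shift either way remains possible.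

For compound 4 the expected step is a 1.5-fold higher number from compound 3 to compound 4 (0.18 log units; within the scatter), within the scatter. Compound 4 is thus estimated at 150 nM, between 60 nM and 400 nM.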

Compound 4, half-maximal inhibitory concentration: 460 nM
Estimate against measurement, compound 4: 3.1-fold (0.49 log units) below; measured number above the stated range.
By their numbers in this assay, from the lowest: compounds 3, 1, 2 and 4 (each within the scatter of the next, the first and the last beyond it).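

In this assay, the carbonyl carbon does not accept every amine group equally: 3-methoxypyrrolidin-1-yl gives a 4.6-fold higher number from compound 3 to compound 4 (0.66 log units; beyond the scatter), and in place of morpholin-4-yl it gives a 2.9-fold higher number from compound 1 to compound 4 (0.46 log units; beyond the scatter). Among these compounds, the earlier exchanges of morpholin-4-yl for (oxolan-3-yl)amino stayed within the scatter, so this is the first change of the group itself, and not of configuration alone, that clearly moves the number. Loss of the amide hydrogen cannot account for this on its own, since compound 1 also lacks that hydrogen and cannot be told apart from compound 3, while a 1.6-fold higher number from compound 2 to compound 4 (0.20 log units; within the scatter) leaves compound 2, which keeps it, level with the new compound within the scatter, and the gap between compound 2 and compound 3 rests on configuration alone: the fact that compounds 2 and 3 differ only in the configuration as drawn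

The compounds shown leave open whether the methoxy group, the pyrrolidine ring or the configuration at the methoxy-bearing carbon sets the number. A plain pyrrolidin-1-yl, a 3-hydroxypyrrolidin-1-yl or the mirror-image arrangement of the 3-methoxypyrrolidin-1-yl would each bear on that question.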